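The source may report more compounds than this note shows. Statements on the series, on what has been measured and on what is new or still open speak of the compounds shown alone.

Of the compounds shown here, two built on the same core have been measured so far. Compound 1 `Oc1cccc(-c2cc(-c3cccs3)cc(-c3cccc(O)c3)n2)c1` gives 3480 nM in a functional assay on HCT-15 cells (Homo sapiens) for cytotoxicity, read by CCK-8 assay (a lower number here means a stronger inhibitor, a higher number a weaker inhibitor), and compound 2 `Oc1cccc(-c2cc(-c3ccoc3)cc(-c3cccc(O)c3)n2)c1` gives 1020 nM in the same test. Among the compounds with values here, the one step between them, a 3.4-fold lower number from compound 1 to compound 2 (0.53 log units; beyond the scatter), is the only measured change so far. Within the data shown here, on these two numbers compound 2 stands lowest, with compound 1 the only neighbour at a higher value.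

The next compound, compound 3 `Oc1cccc(-c2cc(-c3ccccn3)cc(-c3cccc(O)c3)n2)c1`, differs from compound 2 in one place: pyridin-2-yl in place of furan-3-yl on an aromatic carbon. The exchange sits on an aromatic carbon of a six-membered aromatic ring with one nitrogen, meta to two 3-hydroxyphenyl groups and opposite the ring nitrogen.

Among the measured compounds shown here, no measured step swaps a five-membered heteroaryl for a six-membered one here; the only comparison on hand, a 3.4-fold lower number from compound 1 to compound 2 (0.53 log units; beyond the scatter), shows that changing the group at this position can move the number modestly. On that basis he expects compound 3 to land near compound 2, with a step of a 1.5-fold higher number from compound 2 to compound 3 (0.17 log units; within the scatter) that may not exceed the scatter. His estimate for compound 3 is 1500 nM, within a range from 500 nM to 5000 nM.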

Compound 3, half-maximal inhibitory concentration: 3510 nM
The estimate for compound 3 lay 2.3-fold (0.37 log units) below the measured number; low and high end bracket the measured number.
By their numbers in this assay, from the lowest: compound 2; then compounds 1 and 3 (each within the scatter of the next).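

In this assay the group on the aromatic carbon opposite the ring nitrogen now shows a second exchange that moves the number beyond the scatter, with pyridin-2-yl in place of furan-3-yl giving a 3.4-fold higher number from compound 2 to compound 3 (0.54 log units; beyond the scatter) and thus setting compound 2 apart from both other compounds. Pyridin-2-yl in place of thiophen-2-yl gives a 1.0-fold higher number from compound 1 to compound 3 (0.00 log units; within the scatter), so a five-membered and a six-membered aromatic ring cannot be told apart here, and ring size alone does not sort the three compounds: compound 1 and compound 3 go against any such reading, since compound 1 carries a five-membered ring as compound 2 does yet sits with compound 3. Nothing at hand explains why furan-3-yl alone stands apart among these three groups.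

On these data alone, it remains open whether the isomeric furan-2-yl or pyridin-3-yl would stay with compound 2 or with the other two, and whether an amine, a carboxylic acid or a longer chain at this position would take the number lower still. The compounds shown also all keep both 3-hydroxyphenyl groups, so what a methoxy group in place of either hydroxyl would do remains unknown.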